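Moving one fluorine on a potent urea

This account rests on a few compounds, and the source may have more. Where it says the series, first, only, none or still open, it means among the compounds named here.

Compound 1 `O=C(Nc1cccc(F)c1)N1c2ccnn2CC1c1ccccc1` gives > 1000 nM (a limit)
Compound 2 `NC(=O)c1cnn2c1N(C(=O)Nc1ccccc1F)C(c1ccccc1)C2` gives 6.2 nM (a measured number)

Among the measured compounds shown here, in a functional assay on cells (Neutrophil, Homo sapiens) for inhibition, with a stated time of 10 min (a higher number here means a weaker inhibitor, a lower number a stronger inhibitor), compound 2 (6.2 nM) holds the only actual number so far. For compound 1 the reading (> 1000 nM) is a limit of the assay, not a number. Compound 3 `NC(=O)c1cnn2c1N(C(=O)Nc1cccc(F)c1)C(c1ccccc1)C2` has not yet been measured. It keeps the structure of compound 2 except for one change: 3-fluorophenyl in place of 2-fluorophenyl on an amide-type nitrogen, which puts 3-fluorophenyl in place of 2-fluorophenyl on an amide-type nitrogen. For the measured compounds named here, no measured step between single-place neighbours is available to gauge such a swap, so the expectation rests on compound 2 (6.2 nM) alone and stays wide. A modest loss is expected, an estimated (a 2.4-fold higher number from compound 2 to compound 3 (0.38 log units; beyond the scatter)) toward weaker inhibition. The expected value for compound 3 is 15 nM (expected range 2 nM to 150 nM).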

Compound 3, half-maximal inhibitory concentration: 1.2 nM
Estimate against measurement, compound 3: 13-fold (1.10 log units) above, and the stated range ends above it.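

In this assay, the position of a single fluorine proves to matter on its own: 3-fluorophenyl in place of 2-fluorophenyl on the amide-type nitrogen gives a 5.2-fold lower number from compound 2 to compound 3 (0.71 log units; beyond the scatter), with the same atoms joined differently. Compound 1, which also carries 3-fluorophenyl, reads > 1000 nM, and this is a limit of the assay. With 3-fluorophenyl held in both, carbamoyl in place of hydrogen on an aromatic carbon gives an at least 830-fold lower number from compound 1 to compound 3 (2.92 log units; beyond the scatter), a size that can be stated only as a bound set by that limit: the limit of > 1000 nM in this assay, at which 1 of the 3 values shown sits.

The compounds shown leave open how plain phenyl or a chlorophenyl would read on that nitrogen, and whether a nitrile or a carboxylic acid could replace carbamoyl. They also give no reason why moving the fluorine changes the read-out.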